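Swapping the Amide Substituent of a Receptor Agonist

The source may report more compounds than this note shows. Statements on the series, on what has been measured and on what is new or still open speak of the compounds shown alone.

In a functional assay on CHO cells for agonist activity at Free fatty acid receptor 2 (Homo sapiens), read by cAMP accumulation (on this read-out lower numbers stand for smaller maximal responses and higher numbers for larger maximal responses), compound 1 `CNC(=O)[C@H](c1ccc(Cl)cc1)C(C)C` gives 66%. Compound 2 `CC(C)[C@H](C(=O)NC(C)(C)C)c1ccc(Cl)cc1` is reported only as a limit of this assay, < 30%. Compound 3 `CC(C)[C@H](C(=O)Nc1nncs1)c1ccc(Cl)cc1` gives 115%, the highest of the two numbers, with compound 1 nearest. The lone remaining value is the limit reported for compound 2, (the limit of < 30% in this assay, at which 1 of the 3 values shown sits). The three differ only in the group on the amide-type nitrogen, and the steps are large: a number at least 36 percentage points lower from compound 1 to compound 2 (beyond the scatter), a number 49 percentage points higher from compound 1 to compound 3 (beyond the scatter) and a number at least 85 percentage points higher from compound 2 to compound 3 (beyond the scatter).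

Compound 4 `CC(C)[C@H](C(=O)Nc1ccon1)c1ccc(Cl)cc1` differs from compound 3 in one place: 1,2-oxazol-3-yl in place of 1,3,4-thiadiazol-2-yl on an amide-type nitrogen. Both groups are one five-membered aromatic ring, so the step looks smaller than the swings seen from methyl or tert-butyl to the ring of compound 3. The expectation for compound 4 is a modest drop, a number 20 percentage points lower from compound 3 to compound 4 (beyond the scatter), with wide uncertainty. Compound 4 is therefore estimated at 95%, between 60% and 125%.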

Compound 4, largest response reached (reported as efficacy), in percent of the reference or control that the assay uses: 90%
Estimate against measurement, compound 4: 5 percentage points above, within the range that was stated.
By their numbers in this assay, from the lowest: compound 1; then compound 4; then compound 3. At a limit, below all of these: compound 2.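

A second five-membered aromatic ring, 1,2-oxazol-3-yl, also gives a larger maximal response than methyl on the amide-type nitrogen in this assay (a number 24 percentage points higher from compound 1 to compound 4 (beyond the scatter)), so the gain is not confined to the 1,3,4-thiadiazol-2-yl group of compound 3. The two rings are still not interchangeable (a number 25 percentage points lower from compound 3 to compound 4 (beyond the scatter)), so the identity of the ring matters as well as its presence, although these data do not show which difference between the rings is responsible. The 1,2-oxazol-3-yl group also keeps a wide margin over tert-butyl (a number at least 60 percentage points higher from compound 2 to compound 4 (beyond the scatter)), but this step starts from a limit for compound 2 rather than a number: the limit of < 30% in this assay, at which 1 of the 4 values shown sits.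

The compounds shown leave open whether a plain phenyl ring on the amide-type nitrogen would give a similar response. They also leave open whether a pyridin-2-yl ring, with six ring atoms, would do so.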